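Ester to anilide step: cytotoxicity working notes

The source may report more compounds than this note shows. Statements on the series, on what has been measured and on what is new or still open speak of the compounds shown alone.

Measured so far:
Compound 1 `CCOC(=O)c1cn(-c2nccs2)nc1CC(C)C` gives > 100000 nM in a toxicity assay on HepG2 2.2.15 cells (Homo sapiens) for cytotoxicity, read by CCK-8 assay, with a stated time of 8 days; on this read-out lower numbers stand for higher toxicity in this test and higher numbers for lower toxicity in this test; this is a limit of the assay, not a number.
Compound 2 `CCOC(=O)c1cn(-c2ccc([N+](=O)[O-])cc2)nc1CC(C)C` gives > 100000 nM in this assay; this too is a limit, not a number.

Compound 1 therefore stands only at the limit, and the two measured values show no difference between compound 1 and compound 2, since both sit at the limit of > 100000 nM in this assay, at which 2 of the 2 values shown sit. Among the compounds with values here, no step between measured compounds is available, so nothing measured bears directly on the change to be made.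

Compound 3 `CC(C)Cc1nn(-c2nccs2)cc1C(=O)Nc1ccc(F)cc1` differs from compound 1 by (4-fluorophenyl)amino in place of ethoxy on a carbonyl carbon, in words (4-fluorophenyl)amino in place of ethoxy on a carbonyl carbon. With both shown values at the limit, the expectation rests only on the absence of toxicity so far: a small step toward somewhat higher toxicity, or none beyond the scatter, is expected, with a fair chance that the assay again reports only a limit. The expected step of an at least 1.4-fold lower number from compound 1 to compound 3 (0.15 log units; that floor lies within the scatter) is modest. Compound 3 is estimated at 70000 nM, within 20000 nM to 150000 nM.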

Compound 3, half-maximal cytotoxic concentration: 83700 nM
For compound 3 the middle estimate is 1.2-fold (0.08 log units) below the measured one; measured number inside the range.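

Putting (4-fluorophenyl)amino in place of ethoxy on a carbonyl carbon gives, in compound 3, the only value in this assay shown so far that is a number rather than a limit, so this position can bring the read-out into the measurable range. Going by these compounds, the change gives an at least 1.1-fold lower number from compound 1 to compound 3 (0.07 log units; that floor lies within the scatter); this printed floor does not establish a real rise in toxicity, and the full size of the step remains unknown, as compound 1 provides only a limit for its starting point. Even so, the shown set remains largely at the limit of the assay: the limit of > 100000 nM in this assay, at which 2 of the 3 values shown sit.

The compounds shown do not separate the contribution of the amide hydrogen from that of the 4-fluorophenyl ring, and a simple methylamino group, an unsubstituted phenylamino group or a carboxylic acid on the same carbonyl carbon would be needed to tell these apart. Also open, on these data alone, is whether (4-fluorophenyl)amino in place of ethoxy gives a similar result on the core of compound 2, which carries the 4-nitrophenyl group instead of the thiazole ring of compound 1.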